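The source may hold more compounds than are shown below. What is called first, only, known or untested is meant among the compounds shown, and "the series" means these compounds.

Compound 3 `COC[C@H]1CN(c2ccc(-n3cc(-c4ccccn4)cn3)c(F)c2)C(=O)O1` is one of three compounds sharing a core, differing only in the side chain on a saturated ring carbon. In a physicochemical assay for lipophilicity, read by HPLC, measured as octanol-water partition (on this read-out higher numbers stand for higher lipophilicity and lower numbers for lower lipophilicity), compound 3 gives 2.18, the lowest of the three numbers, though within the scatter of both neighbours: compound 1 `CN1CCN(C[C@H]2CN(c3ccc(-n4cc(-c5ccccn5)cn4)c(F)c3)C(=O)O2)CC1` gives 2.2 and compound 2 `CCN1CCN(C[C@H]2CN(c3ccc(-n4cc(-c5ccccn5)cn4)c(F)c3)C(=O)O2)CC1` gives 2.19. The measured steps of a number 0.02 log units lower from compound 1 to compound 3 (within the scatter) and a number 0.01 log units lower from compound 2 to compound 3 (within the scatter) show that swapping a piperazine ring for a methoxy group at this position left this assay essentially unchanged, as did a number 0.01 log units lower from compound 1 to compound 2 (within the scatter).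

Compound 4 `CCC(=O)NC[C@H]1CN(c2ccc(-n3cc(-c4ccccn4)cn3)c(F)c2)C(=O)O1` carries a different side chain: propanoylamino in place of methoxy on a saturated chain carbon bound to a saturated ring carbon. Among the compounds with values here, no measured step involves an amide group, so the earlier steps bear only loosely on this change; they indicate that this position tolerates side-chain variation without a large shift in this assay. The entering group brings a hydrogen-bond donor that the leaving methoxy lacks, alongside two more carbons. The step of a number 0.18 log units lower from compound 3 to compound 4 (within the scatter) is therefore expected to be small and likely downward. Compound 4 is estimated at 2, within the range 1.6 to 2.4.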

Compound 4, partition coefficient: 2.2
Compound 4: middle estimate off by 0.20 log units, on the low side; the measured number falls inside the stated range.
By their numbers in this assay, from the lowest: compounds 3, 2, 1 and 4 (each within the scatter of the next).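

In this assay the amide side chain gives a number 0.02 log units higher from compound 3 to compound 4 (within the scatter) and also a number 0.01 log units higher from compound 2 to compound 4 (within the scatter) and no change at the digits printed from compound 1 to compound 4 (within the scatter) at this place, on a saturated chain carbon bound to a saturated ring carbon. The earlier compounds shown here compared methoxy and the two piperazine side chains, whereas propanoylamino adds a carbonyl and a hydrogen-bond donor that methoxy lacks, and the read-out still does not separate it from the other three. Nothing measured here explains why these four side chains read alike.

The compounds shown leave open whether a carboxylic acid, a primary amine or a much longer carbon chain at this place would also stay within the scatter of these four. They also leave open whether a simple hydroxyl group would do the same.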